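A few compounds are considered here, and "the series" means these few. Any claim that something is new, unique, unknown or untested is made for them only; others in the source may bear on it.

Compound 1 `CN(C)C(=O)Cn1c(-c2ccc(Br)cc2)nc2cccnc21` gives 7 mg/kg in a functional assay on the whole organism with Mus musculus as the target; a higher number here means that more compound is needed for the effect, a lower number that less compound is needed.
Compound 2 `CN(C)C(=O)Cn1c(-c2ccc(F)cc2)nc2cccnc21` gives 40.5 mg/kg in this assay.
Compound 3 `CCCNC(=O)Cn1c(-c2ccc(Cl)cc2)nc2cccnc21` gives 37.5 mg/kg in this assay.

Among these three numbers compound 3 stands second highest. Compound 2 lies nearest to it, within the scatter, so no order between the two can be read. Compound 1 lies furthest from it, with a lower number beyond the scatter. Among the measured compounds shown here, the only step between two compounds that differ in a single place is a 5.8-fold higher number from compound 1 to compound 2 (0.76 log units; beyond the scatter), fluoro in place of bromo on an aromatic carbon.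

Compound 4 `CN(C)CCN(C)C(=O)Cn1c(-c2ccc(Cl)cc2)nc2cccnc21` differs from compound 3 at the amide: (2-(dimethylamino)ethyl)(methyl)amino in place of propylamino on a carbonyl carbon. For the measured compounds named here, no measured pair differs in this way. Going by the values given here, the one measured step concerns the halogen on the aromatic carbon and says nothing about the group on the carbonyl carbon. Compounds 1 and 2 share one amide substituent and compound 3 carries another, but as they also differ in the halogen, their values cannot be taken apart. Among the compounds with values here, the account therefore expects no step beyond the scatter in this assay, with a wide range because no bearing step exists. The expected step is a 1.1-fold lower number from compound 3 to compound 4 (0.03 log units; within the scatter). Compound 4 is estimated at 35 mg/kg, within 12 mg/kg to 100 mg/kg.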

Compound 4, dose for half-maximal effect: 100 mg/kg
For compound 4 the middle estimate is 2.9-fold (0.46 log units) below the measured one; the measured number falls inside the stated range.
By their numbers in this assay, from the lowest: compound 1; then compounds 3 and 2 (each within the scatter of the next); then compound 4.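

Among the compounds shown here, with the rest of the structure unchanged, (2-(dimethylamino)ethyl)(methyl)amino in place of propylamino on the carbonyl carbon gives a 2.7-fold higher number from compound 3 to compound 4 (0.43 log units; beyond the scatter) in this assay, the first measured step at this position, which the halogen step among the earlier compounds could not supply. The result shows that the group on the carbonyl carbon is not neutral in this assay: this exchange moves the number beyond the scatter towards more compound being needed, although a single step combines several changes, namely a longer group, a second nitrogen and the loss of the amide hydrogen. Nothing given here explains the step or ties it to any property of the entering group.

The compounds shown leave open which of these changes carries the step, and a simple dimethylamino group on the carbonyl carbon with the chloro substituent kept, or a butyl chain in place of propylamino, would bear on that question. On these data alone, it also remains open whether the same step holds with bromo on the aromatic carbon, and how a morpholine or a carboxylic acid at the end of the chain would read.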